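The compounds below may be only part of what the source reports. "The series", "measured", "known", "first", "only" and "open" are said of these compounds alone.

In a functional assay on A549 cells (Homo sapiens) for antiproliferative activity, read by MTT assay, with a stated time of 72 h (a higher number here means a weaker inhibitor, a lower number a stronger inhibitor), compound 1 (`O=S1(=O)C=Cc2ccc(Nc3cccc(C(F)(F)F)c3)cc21`) gives 1440 nM and sits within the scatter of the two other measured compounds. Compound 2 (`COc1ccc(Nc2ccc3c(c2)S(=O)(=O)C=C3)cc1`) stands at 1220 nM and compound 3 (`COc1cc(Nc2ccc3c(c2)S(=O)(=O)C=C3)cc(OC)c1OC`) at 1880 nM with no gap among the three that exceeds the scatter. Among the compounds with values here, no two of these measured compounds differ in one place only, so no direct step guides what follows. Compound 4 (`O=S1(=O)C=Cc2ccc(Nc3cccc(OC(F)(F)F)c3)cc21`) matches compound 1 except for trifluoromethoxy in place of trifluoromethyl on an aromatic carbon meta to a large group. Compound 2 at 1220 nM and compound 3 at 1880 nM carry substituents other than that of compound 1, yet their numbers stay within the scatter of it, so in this assay no shift beyond the scatter is expected in either direction. The expected change is a 1.1-fold lower number from compound 1 to compound 4 (0.04 log units; within the scatter) and would lie within the scatter. Compound 4 is estimated at 1300 nM with an expected range from 650 nM to 2600 nM for repeated measurements.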

Compound 4, half-maximal inhibitory concentration: 1370 nM
Compound 4: middle estimate off by 1.1-fold (0.02 log units), on the low side, within the range that was stated.
By their numbers in this assay, from the lowest: compounds 2, 4, 1 and 3 (each within the scatter of the next).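

In this assay, within the data shown here, putting trifluoromethoxy in place of trifluoromethyl on an aromatic carbon, meta to a large group, gives a 1.1-fold lower number from compound 1 to compound 4 (0.02 log units; within the scatter) and supplies the first comparison here of compounds that differ in one place only. The earlier compounds shown here differed in more than one place and could not isolate any single group, whereas this pair shows that, at this position, the entering oxygen and its one hydrogen-bond acceptor leave the number within the scatter. No measured property of either group bears on this result, so the pair offers no explanation for it.

As far as these compounds go, whether a group of another kind at this position, such as an amine, a carboxylic acid or a nitrile, would move the number beyond the scatter remains open. Also open, from the compounds shown here alone, is whether trifluoromethoxy in place of trifluoromethyl would give the same result on another aromatic carbon of this ring.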